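Ring Size and Half-Life in Liver Cytosol

A few compounds are considered here, and "the series" means these few. Any claim that something is new, unique, unknown or untested is made for them only; others in the source may bear on it.

Compound 2 `Cn1cc(-c2ccc3nnc(Sc4ccc5ncc(NC6COC6)cc5c4)n3c2)cn1` gives 0.733 h in an ADME assay on cytosol from liver (strain CD1) for pharmacokinetics, with aldehyde oxidase 1 (Mus musculus) as the target, read by LC-MS, with a stated time of 120 min, tested at 1 uM (on this read-out lower numbers stand for a shorter-lived compound and higher numbers for a longer-lived compound), the lowest of the two numbers measured; compound 1 `Cn1cc(-c2ccc3nnc(Sc4ccc5ncc(NC6CCOCC6)cc5c4)n3c2)cn1` gives 5.12 h. Compound 3 `Cn1cc(-c2ccc3nnc(Sc4ccc5ncc(NC6CCOC6)cc5c4)n3c2)cn1` differs from compound 2 by oxolan-3-yl in place of oxetan-3-yl on a nitrogen on an aromatic ring. Among the measured compounds shown here, the one measured step bears on this change: going from oxan-4-yl to oxetan-3-yl shortened the half-life because a 7.0-fold lower number from compound 1 to compound 2 (0.84 log units; beyond the scatter) lies beyond the scatter. Widening the ring again, though not all the way, is expected to recover part of that loss, estimated as a 2.7-fold higher number from compound 2 to compound 3 (0.44 log units; beyond the scatter). Compound 3 is therefore expected to show 2 h, with a range from 0.8 h to 5 h.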

Compound 3, half-life: 0.85 h
The estimate for compound 3 lay 2.4-fold (0.37 log units) above the measured number; the range from low to high includes it.
By their numbers in this assay, from the lowest: compounds 2 and 3 (each within the scatter of the next); then compound 1.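

Oxolan-3-yl in place of oxetan-3-yl gives a 1.2-fold higher number from compound 2 to compound 3 (0.06 log units; within the scatter) at this position, so the half-lives of these two ring sizes cannot be told apart. Oxolan-3-yl in place of oxan-4-yl gives a 6.0-fold lower number from compound 1 to compound 3 (0.78 log units; beyond the scatter) and shows that, among these three compounds, the large gap lies between the six-membered ring and the two smaller rings. No measurement here explains this gap. The compounds shown leave open whether a piperidin-4-yl group or an open 2-methoxyethyl chain on the same nitrogen would give a half-life like that of compound 1.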